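Replacing a Piperidine Side Chain with a Piperazinylethyl Group

The source may hold more compounds than are shown below. What is called first, only, known or untested is meant among the compounds shown, and "the series" means these compounds.

Of the compounds shown here, two have been measured so far in a functional assay on CCRF-CEM cells for antagonist activity at C-X-C chemokine receptor type 4 (Homo sapiens), read by calcium flux, with stated times of 25 min and 90 s; on this read-out lower numbers stand for stronger inhibition and higher numbers for weaker inhibition. Compound 1, `c1ccc2c(c1)CN[C@@H](CN(CC[C@@H]1CCCNC1)[C@H]1CCCc3cccnc31)C2`, gives 161 nM in this assay. Compound 2, `c1ccc2c(c1)CN[C@@H](CN(CC[C@H]1CCCNC1)[C@H]1CCCc3cccnc31)C2`, gives 16 nM in this assay, the lowest of the two numbers. Within the data shown here, the only measured step is a 10-fold lower number from compound 1 to compound 2 (1.00 log units; beyond the scatter), and it rests on the fact that compounds 1 and 2 differ only in the configuration as drawn alone: the two compounds share every atom and bond and differ only at one stereocentre on a saturated ring carbon.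

Compound 3, `c1ccc2c(c1)CN[C@@H](CN(CCCCN1CCNCC1)[C@H]1CCCc3cccnc31)C2`, has not yet been measured. It differs from compound 2 by 2-(piperazin-1-yl)ethyl in place of piperidin-3-yl on a saturated chain carbon, two bonds along the chain from an amine nitrogen. Among the measured compounds shown here, the group that leaves carries the very stereocentre whose configuration made the measured step, so that step gives no direct guidance on what the new group will do, and no other measured pair speaks to a change of this kind. The expectation therefore stays wide. The step from compound 2 to compound 3 is estimated at a 3.8-fold higher number from compound 2 to compound 3 (0.57 log units; beyond the scatter), a moderate weakening that is far from certain. Compound 3 is thus expected to give about 60 nM in this assay, within a range from 10 nM to 400 nM.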

Compound 3, half-maximal inhibitory concentration: 66 nM
Compound 3: middle estimate off by 1.1-fold (0.04 log units), on the low side, and the stated range covers the measured number.
By their numbers in this assay, from the lowest: compound 2; then compound 3; then compound 1.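

The position accepts more than the piperidin-3-yl group: in this assay, 2-(piperazin-1-yl)ethyl brings a second ring nitrogen and a longer reach from the chain, yet activity is kept, with a 4.1-fold higher number from compound 2 to compound 3 (0.62 log units; beyond the scatter). The same replacement compares favourably with the other piperidine isomer, with a 2.4-fold lower number from compound 1 to compound 3 (0.39 log units; beyond the scatter), so the new group falls inside the span set by the two piperidine compounds, matching neither the better isomer nor the poorer one. The group that enters has no defined stereocentre, which shows that useful activity at this place does not depend on having one, whereas the wide gap within the piperidine pair comes from configuration alone: the fact that compounds 1 and 2 differ only in the configuration as drawn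

Because several features change at once in this replacement, the compounds shown cannot separate the effect of the added ethyl linker from that of the second ring nitrogen. Going by these compounds, a group such as 2-(piperidin-1-yl)ethyl or 2-(morpholin-4-yl)ethyl at the same place would help to tell these two changes apart, and the outcome for either remains open.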